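A few compounds are considered here, and "the series" means these few. Any claim that something is new, unique, unknown or untested is made for them only; others in the source may bear on it.

The two measured compounds share a core and differ away from it. Compound 1 `O=C(Nc1ccc(C(=O)N2CCCN(Cc3ccccc3)c3sccc32)cc1)c1ccccc1-c1ccccc1` carries a benzyl group on the fused bicyclic amine and no substituent on the aromatic ring that bears the amide nitrogen. In an assay on CHO cells for inhibition of Vasopressin V2 receptor (Homo sapiens), read by radioligand binding (on this read-out higher numbers stand for weaker inhibition and lower numbers for stronger inhibition), compound 1 gives 80 nM. Compound 2 `CN1CCN(C(=O)CCCOc2cc(C(=O)N3CCCCc4sccc43)ccc2NC(=O)c2ccccc2-c2ccccc2)CC1` instead has an oxygen on that aromatic ring bearing a 3-((4-methylpiperazin-1-yl)carbonyl)propyl chain, and in this assay compound 2 gives 6 nM. Compound 2 thus stands at the lowest number of the two, and its gap to compound 1 lies beyond the usual scatter.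

Compound 3 `O=C(Nc1ccc(C(=O)N2CCCCc3sccc32)cc1O)c1ccccc1-c1ccccc1` has not yet been measured. It differs from compound 2 in one place: hydrogen in place of 3-((4-methylpiperazin-1-yl)carbonyl)propyl on an oxygen on an aromatic ring. Nothing in the measured pair shows directly what this chain contributes, since compound 1 lacks both the oxygen and the chain and also carries the benzyl group. An estimate for compound 3 therefore rests on the two values alone, and a step toward a weaker number, of a 4.2-fold higher number from compound 2 to compound 3 (0.62 log units; beyond the scatter), is expected, smaller than the gap from compound 2 to compound 1. Compound 3 is estimated at 25 nM, with a range from 6 nM to 100 nM.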

Compound 3, half-maximal inhibitory concentration: < 10 nM
Compound 3: a limit, no number; the forecaster's own chance of this, stated with the estimate: 5%; middle value at least 2.5-fold (0.39 log units) away from the limit.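

In this assay compound 3 gives < 10 nM, which is a limit and not a number. For the compounds shown here, no step from compound 2 to compound 3 can therefore be read. The compounds shown leave open how far compound 3 lies from compound 2, and so what replacing the 3-((4-methylpiperazin-1-yl)carbonyl)propyl chain with hydrogen does in this assay.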